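From Acetamido to 1-Methylpiperidin-4-yl

The source may hold more compounds than are shown below. What is called first, only, known or untested is meant among the compounds shown, and "the series" means these compounds.

Among the measured compounds shown here, in an in vivo ADME assay on the whole organism for metabolic stability, with Rattus norvegicus as the target (on this read-out lower numbers stand for a shorter-lived compound and higher numbers for a longer-lived compound), compound 1 (`CC(=O)Nc1ccc(Nc2nc(N)n(-c3ccccn3)n2)cc1`) gives 1.33 h as the lowest of three numbers so far. Compound 2 (`CN1CCN(c2ccc(Nc3nc(N)n(-c4ccccn4)n3)cc2)CC1`) stands at 2.54 h within the scatter of compound 1, and compound 3 (`Nc1nc(Nc2cccc(C(=O)N3CCOCC3)c2)nn1-c1ccccn1`) stands at 2.92 h beyond it. Compound 4 (`CN1CCC(c2ccc(Nc3nc(N)n(-c4ccccn4)n3)cc2)CC1`) has 1-methylpiperidin-4-yl in place of acetamido on an aromatic carbon and has no number yet. For the measured compounds named here, one measured step bears on this: 4-methylpiperazin-1-yl in place of acetamido gave a 1.9-fold higher number from compound 1 to compound 2 (0.28 log units; within the scatter) and so shows no firm change. A step of similar size and direction is therefore expected in this assay with nothing firm beyond the scatter. The expected step is a 1.8-fold higher number from compound 1 to compound 4 (0.26 log units; within the scatter) in this estimate. The estimate for compound 4 is 2.4 h with a range of 1.2 h to 4.6 h for repeat measurements.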

Compound 4, half-life: 2.45 h
Compound 4: the middle estimate sits 1.0-fold (0.01 log units) below what was measured; the measured number falls inside the stated range.
By their numbers in this assay, from the lowest: compounds 1, 4, 2 and 3 (each within the scatter of the next, the first and the last beyond it).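

In this assay a second ring group in place of acetamido on this aromatic carbon gives a 1.8-fold higher number from compound 1 to compound 4 (0.27 log units; within the scatter), so neither ring group yet shows a firm change from acetamido. The new comparison is between the two rings themselves: 1-methylpiperidin-4-yl in place of 4-methylpiperazin-1-yl gives a 1.0-fold lower number from compound 2 to compound 4 (0.02 log units; within the scatter), and this read-out does not separate them. Nothing measured here explains these results. From the compounds shown here alone, it remains open whether a carboxylic acid or a longer chain on this aromatic carbon would shift the half-life beyond the scatter.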